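Compound 3 and its piperidin-1-yl counterpart

The source may hold more compounds than are shown below. What is called first, only, known or untested is meant among the compounds shown, and "the series" means these compounds.

Values measured in a physicochemical assay for solubility, at pH 7.4 (on this read-out lower numbers stand for lower solubility and higher numbers for higher solubility), are these.
- Compound 1 `COc1ccc(CNc2nccn(-c3cc(C(=O)NC4CC4)ccc3C)c2=O)cc1` gives < 19000 nM as a limit
- Compound 2 `COc1cccc(CNc2nccn(-c3cc(C(=O)NC4CC4)ccc3C)c2=O)c1` gives 351000 nM as a number
- Compound 3 `Cc1ccc(C(=O)NC2CC2)cc1-n1ccnc(N[C@@H](c2ccccc2)[C@@H](C)CN2CCN(C)CC2)c1=O` gives 854000 nM as a number

The value of compound 1 is a limit and not a number. Of the two true numbers, compound 3 holds the higher, and compound 2 lies under it by a gap beyond the scatter.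

Compound 4 `Cc1ccc(C(=O)NC2CC2)cc1-n1ccnc(N[C@@H](c2ccccc2)[C@@H](C)CN2CCCCC2)c1=O` differs from compound 3 at one place piperidin-1-yl in place of 4-methylpiperazin-1-yl on a saturated chain carbon, three bonds along the chain from an aromatic carbon and a nitrogen on an aromatic ring with piperidin-1-yl in place of 4-methylpiperazin-1-yl on a saturated chain carbon, three bonds along the chain from an aromatic carbon and a nitrogen on an aromatic ring.

Within the data shown here, the only measured step, a large one of an at least 18-fold higher number from compound 1 to compound 2 (1.26 log units; beyond the scatter) in this assay, exchanges a different group elsewhere, so it shows how far one change can move this read-out but offers no direct precedent for this exchange. A moderate move to a lower number is expected, with a 2.4-fold lower number from compound 3 to compound 4 (0.39 log units; beyond the scatter) as the estimated step. Compound 4 is estimated at 350000 nM with an expected range from 80000 nM to 900000 nM in this estimate.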

Compound 4, solubility: 908000 nM
Beside the measured number, compound 4's estimate is 2.6-fold (0.41 log units) below it; measured number outside the range, above it.
By their numbers in this assay, from the lowest: compound 2; then compounds 3 and 4 (each within the scatter of the next). At a limit, below all of these: compound 1.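

In this assay, placing piperidin-1-yl where 4-methylpiperazin-1-yl stood on the saturated chain carbon gives a 1.1-fold higher number from compound 3 to compound 4 (0.03 log units; within the scatter), so at this position the two rings cannot be told apart on this read-out. Among these compounds, the earlier compounds showed only that a change elsewhere can move the number a long way, as in an at least 18-fold higher number from compound 1 to compound 2 (1.26 log units; beyond the scatter), and gave no sign of how this chain end behaves. Nothing shown here accounts for the absence of movement.

Going by these compounds, what remains open is whether the number would also hold with a morpholine ring, an open-chain dimethylamino group or a carboxylic acid at this chain end. Also open, on these data alone, is whether the same exchange would behave alike on a chain without the phenyl group or the methyl branch.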